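The source may hold more compounds than are shown below. What is called first, only, known or untested is meant among the compounds shown, and "the series" means these compounds.

Measured so far in a toxicity assay on Vero cells (Chlorocebus sabaeus) for cytotoxicity, read by MTT assay (a higher number here means a weaker inhibitor, a lower number a stronger inhibitor), as follows:
- compound 1 `O=C(Nc1sccc1C(=O)Nc1ccccn1)c1ccc(S(=O)(=O)N2CCCCC2)cc1` gives "nd" (no result reported)
- compound 2 `CC(C)OC(=O)NC(=O)c1ccsc1NC(=O)c1ccc(S(=O)(=O)N2CCOCC2)cc1` gives 13.1 ug/mL
- compound 3 `CCCOC(=O)NC(=O)c1ccsc1NC(=O)c1ccc(S(=O)(=O)N2CCOCC2)cc1` gives "nd" (no result reported)

Compound 1 therefore has no single number to stand on, and compound 3 shares that position. Going by the values given here, compound 2 supplies the only numerical reading. Still to be measured in this assay is compound 4 `CCOC(=O)NC(=O)c1ccsc1NC(=O)c1ccc(S(=O)(=O)N2CCCCC2)cc1` as the next entry.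

The structural change is ethoxycarbonyl in place of pyridin-2-yl on an amide-type nitrogen, with the rest of the structure untouched.

Without a number for compound 1, the size of this step cannot be anchored at its starting point. Among the compounds with values here, no direction is favoured, and no step beyond the usual scatter is expected relative to the one available reading. The estimate therefore rests on compound 2 at 13.1 ug/mL with a wide margin, since that compound is the only reference.

For compound 4 the expected value is 15 ug/mL in an estimated range of 5 ug/mL to 50 ug/mL overall.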

Compound 4, half-maximal inhibitory concentration: 18.6 ug/mL
For compound 4 the middle estimate is 1.2-fold (0.09 log units) below the measured one; low and high end bracket the measured number.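

In this assay, going by these compounds alone, compound 1 has no single number, so no step to compound 4 can be read. The compounds shown leave open what ethoxycarbonyl in place of pyridin-2-yl does to the read-out. No supporting evidence bears on this result.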